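Moving the Fluorine on the Phenyl Group of Compound 1

The source may report more compounds than this note shows. Statements on the series, on what has been measured and on what is new or still open speak of the compounds shown alone.

In a functional assay on HL-60 cells (Homo sapiens) for inhibition, read by MTT assay, with a stated time of 72 h (on this read-out lower numbers stand for stronger inhibition and higher numbers for weaker inhibition), compound 1 `COc1cccc(N2CCN(C(=O)c3oc(C)nc3-c3ccccc3F)CC2)c1` gives 56.1 nM, the middle of three measured numbers. Compound 2 `COc1ccc(Cl)cc1N1CCN(C(=O)c2oc(C)nc2-c2ccccc2F)CC1` gives 153 nM, and compound 3 `COc1cc(OC)cc(N2CCN(C(=O)c3oc(C)nc3-c3ccccc3F)CC2)c1` gives 10.3 nM. The unmeasured compound 4 `COc1cccc(N2CCN(C(=O)c3oc(C)nc3-c3cccc(F)c3)CC2)c1` carries 3-fluorophenyl in place of 2-fluorophenyl on an aromatic carbon. Three measured steps exist: a 2.7-fold higher number from compound 1 to compound 2 (0.44 log units; beyond the scatter), a 5.4-fold lower number from compound 1 to compound 3 (0.74 log units; beyond the scatter) and a 15-fold lower number from compound 2 to compound 3 (1.17 log units; beyond the scatter). All three changed the group on an amine nitrogen in a ring, and none changed the fluorophenyl group. They show how far the number can move, but they give no direction for this change. Only a small shift, possibly within the scatter, is therefore expected, and it could go either way. The expected step is a 1.1-fold higher number from compound 1 to compound 4 (0.03 log units; within the scatter). For compound 4 the estimated value is 60 nM, with an expected range of 20 nM to 180 nM.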

Compound 4, half-maximal inhibitory concentration: "not active" (no number reported)
For compound 4 the study gives words and no number; the estimate stays without a comparison.
By their numbers in this assay, from the lowest: compound 3; then compound 1; then compound 2.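

Within the data shown here, compound 4 is described in this assay only as "not active", with no number, so no step from compound 1 can be read. Nothing shown here explains this result. The compounds shown leave open how much 3-fluorophenyl in place of 2-fluorophenyl changes the number.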